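Demethylating a pyrazole-linked urea: methoxy to hydroxy

A few compounds are considered here, and "the series" means these few. Any claim that something is new, unique, unknown or untested is made for them only; others in the source may bear on it.

Compound 3 `COc1cc(-c2nn(-c3cccc(NC(=O)Nc4ccc(Cl)c(C(F)(F)F)c4)c3)cc2-c2ccncc2)ccc1Cl` carries the only number among the three results shown: in a functional assay on OVCAR-4 cells (Homo sapiens) for inhibition, read by sulforhodamine B assay, with a stated time of 48 h (on this read-out lower numbers stand for stronger inhibition of growth and higher numbers for weaker inhibition of growth), compound 3 gives 25600 nM. Compound 1 `O=C(Nc1cccc(-n2cc(-c3ccncc3)c(-c3ccc(Cl)c(O)c3)n2)c1)Nc1cccc(C(F)(F)F)c1` reaches only a limit in this assay, > 32500 nM. Compound 2 `O=C(Nc1cccc(-n2cc(-c3ccncc3)c(-c3ccc(Cl)c(O)c3)n2)c1)Nc1ccc(Cl)c(Cl)c1` likewise stops at a limit, > 32500 nM. Going by the values given here, the single measured step, a step that the two limits leave unreadable from compound 1 to compound 2, concerns the aryl on the urea and is not readable because of the limit of > 32500 nM in this assay, at which 2 of the 3 values shown sit. Compound 4 `O=C(Nc1cccc(-n2cc(-c3ccncc3)c(-c3ccc(Cl)c(O)c3)n2)c1)Nc1ccc(Cl)c(C(F)(F)F)c1` differs from compound 3 by hydrogen in place of methyl on an oxygen on an aromatic ring. Among the compounds with values here, no measured pair shows this change; compound 1 and compound 2 share the hydroxy of compound 4 and sit at the limit. Compound 4 is therefore expected to shift by a 1.3-fold higher number from compound 3 to compound 4 (0.10 log units; within the scatter), a step within the scatter that may well end at the limit, with an estimate of 32000 nM spanning 12000 nM to 80000 nM.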

Compound 4, concentration for total growth inhibition: > 32500 nM
Compound 4 ended at the assay's limit; the forecaster's own chance of this, stated with the estimate: 55%; at least 1.0-fold (0.00 log units) between middle value and limit.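

The methoxy to hydroxy change now has its first measured pair: in this assay, it gives an at least 1.2-fold higher number from compound 3 to compound 4 (0.10 log units; that floor lies within the scatter). Compound 4 stands at a limit of the assay, not at a number, so this step is only a floor, and with this hydroxy all three compounds sit at that limit. The steps linking compound 4 to compound 1 and compound 2 cannot be read, because those values share one limit: the limit of > 32500 nM in this assay, at which 3 of the 4 values shown sit.

On these data alone, the true size of the step stays open. So does whether an ethoxy or an amine in place of the methoxy would give a readable number.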